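Notes on the dimethylpyrrole step in this series

This account rests on a few compounds, and the source may have more. Where it says the series, first, only, none or still open, it means among the compounds named here.

Compound 3 `COC1=CC(c2cc3ccccc3n2C(=O)OC(C)(C)C)=N/C1=C\c1ccc[nH]1` is measured in a functional assay on PLC5 cells (Homo sapiens) for cytotoxicity, read by MTT assay (a higher number here means a weaker inhibitor, a lower number a stronger inhibitor), only as a limit, > 40000 nM. The same limit holds for compound 1 `COc1cc(-c2cc3ccccc3n2C(=O)OC(C)(C)C)[nH]c1/C=C1/SC(=O)NC1=O`, which gives > 40000 nM. Among the measured compounds shown here, compound 2 `COC1=CC(c2cc3ccccc3[nH]2)=N/C1=C\c1ccc[nH]1` gives 13200 nM; the step of an at least 3.0-fold higher number from compound 2 to compound 3 (0.48 log units; beyond the scatter) is the only measured step, and it concerns the tert-butoxycarbonyl group, not the pyrrole. Compound 4 `COC1=CC(c2cc3ccccc3n2C(=O)OC(C)(C)C)=N/C1=C\c1[nH]c(C)cc1C` differs from compound 3 by 3,5-dimethyl-1H-pyrrol-2-yl in place of 1H-pyrrol-2-yl on a double-bonded chain carbon bound to a double-bonded ring carbon. For the measured compounds named here, no measured step bears on this change, so nothing here sets its size or direction; the position of compound 3 at the limit of > 40000 nM in this assay, at which 2 of the 3 values shown sit, is the only guide. Compound 4 is therefore expected at or near that limit, with the step of a number no higher from compound 3 to compound 4 (the limit leaves the size open) assumed to be within the scatter. The estimate for compound 4 is 40000 nM, between 15000 nM and 100000 nM.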

Compound 4, half-maximal inhibitory concentration: 28400 nM
Estimate against measurement, compound 4: 1.4-fold (0.15 log units) above; the range from low to high includes it.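

With 3,5-dimethyl-1H-pyrrol-2-yl on the double-bonded chain carbon, compound 4 is the only tert-butoxycarbonyl compound shown that has a measured number rather than a limit in this assay. The change gives an at least 1.4-fold lower number from compound 3 to compound 4 (0.14 log units; that floor lies within the scatter), so no change in either direction is established. The true size stays unfixed because compound 3 is held only by a limit: the limit of > 40000 nM in this assay, at which 2 of the 4 values shown sit.

Going by these compounds, whether the same change would shift compound 2, which lacks tert-butoxycarbonyl, remains open. So does the outcome with an ethyl group in place of the methyl groups, or with a carboxylic acid on the pyrrole.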